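This account rests on a few compounds, and the source may have more. Where it says the series, first, only, none or still open, it means among the compounds named here.

Series notes. Compound 1 `N[C@@H](CO)[C@H](O)/C=C/CCCCCCc1ccc(I)cc1` and compound 2 `N[C@@H](CO)[C@H](O)/C=C/CCCCCCCCc1ccc(I)cc1` share the same head group and differ only in the length of the saturated chain that carries the iodinated ring. In an assay on isolated protein for inhibition of sphingosine kinase 1 (Homo sapiens) (on this read-out higher numbers stand for weaker inhibition and lower numbers for stronger inhibition), compound 1 gives 3960 nM and compound 2 gives 500 nM; compound 2 thus stands at the lower of the two numbers, and its gap to compound 1 lies beyond the usual scatter. Compound 3 `N[C@@H](CO)[C@H](O)/C=C/CCCCCCCCCc1ccc(I)cc1` carries the change (4-iodobenzyl in place of 4-iodophenyl on a saturated chain carbon, eight bonds along the chain from a double-bonded chain carbon). Going by the values given here, no step between measured neighbours is available; the two values show that the longer chain went with the lower number. For compound 3 a modest move in the same direction, toward a lower number, is expected in this assay, although a result within the scatter of compound 2 would not be surprising. The expected step is a 1.7-fold lower number from compound 2 to compound 3 (0.22 log units; within the scatter). Compound 3 is estimated at 300 nM in this assay, with a range from 100 nM to 900 nM.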

Compound 3, half-maximal inhibitory concentration: 2780 nM
For compound 3 the middle estimate is 9.3-fold (0.97 log units) below the measured one, and the stated range ends below it.
By their numbers in this assay, from the lowest: compound 2; then compounds 3 and 1 (each within the scatter of the next).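

In this assay, 4-iodobenzyl in place of 4-iodophenyl on a saturated chain carbon, eight bonds along the chain from a double-bonded chain carbon, gives a 5.6-fold higher number from compound 2 to compound 3 (0.75 log units; beyond the scatter) and so shows that extending the chain at this position does not keep lowering the number. Compound 3 at 2780 nM and compound 1 at 3960 nM lie within the scatter of each other, which leaves compound 2 alone at the low end of the three, and compound 3 goes against the trend suggested by compound 1 and compound 2. Nothing on hand accounts for this reversal.

Going by these compounds, whether a still longer chain would raise the number further remains open. So does whether a 4-bromophenyl or 4-chlorophenyl group at this position would behave like 4-iodophenyl.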